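The source may hold more compounds than are shown below. What is called first, only, known or untested is meant among the compounds shown, and "the series" means these compounds.

Among the measured compounds shown here, compound 1 `CC[C@]1(C(=O)O)CC[C@H](C(=O)N2CC[C@](c3ccc(C(F)(C(F)(F)F)C(F)(F)F)cc3)(S(=O)(=O)c3ccc(F)cc3)C2)CC1` gives 100% in an ADME assay on microsomes from liver (Homo sapiens) for metabolic stability, with a stated time of 10 min (on this read-out lower numbers stand for a less stable compound and higher numbers for a more stable compound), the highest of the three numbers measured so far. Compound 2 `C[C@]1(C(=O)N2CC[C@](c3ccc(C(F)(C(F)(F)F)C(F)(F)F)cc3)(S(=O)(=O)c3ccc(F)cc3)C2)CC[C@H](C(=O)O)CC1` gives 80% in this assay, and compound 3 `C[C@]1(C(=O)N2CC[C@](c3ccc(C(F)(C(F)(F)F)C(F)(F)F)cc3)(S(=O)(=O)c3ccc(F)cc3)C2)CC[C@@H](C(=O)O)CC1` gives 85%; the step of a number 5 percentage points higher from compound 2 to compound 3 (within the scatter) lies within the scatter, a comparison that rests on (the fact that compounds 2 and 3 differ only in the configuration as drawn). Compound 4 `O=C(O)C12CCC(C(=O)N3CC[C@](c4ccc(C(F)(C(F)(F)F)C(F)(F)F)cc4)(S(=O)(=O)c4ccc(F)cc4)C3)(CC1)OC2` has not yet been measured; it differs from compound 1 by a group of 11 heavy atoms (8 carbon, 3 oxygen; one six-membered non-aromatic ring of carbon only, one six-membered non-aromatic ring with 1 hetero atom) in place of a group of 11 heavy atoms (9 carbon, 2 oxygen; one six-membered non-aromatic ring of carbon only), on a carbonyl carbon. The measured steps that bear on this change are the two that likewise remove the 4-carboxy-4-ethylcyclohexyl group from the carbonyl carbon: a number 20 percentage points lower from compound 1 to compound 2 (beyond the scatter) and a number 15 percentage points lower from compound 1 to compound 3 (beyond the scatter), both modest falls beyond the scatter. One therefore expects a modest fall, a number 15 percentage points lower from compound 1 to compound 4 (beyond the scatter). Compound 4 is estimated at 85%, with a range from 65% to 100%.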

Compound 4, percent of the compound remaining: 90%
Compound 4: middle estimate off by 5 percentage points, on the low side; the range from low to high includes it.
By their numbers in this assay, from the lowest: compounds 2, 3, 4 and 1 (each within the scatter of the next, the first and the last beyond it).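

In this assay, among the compounds shown here, the group with the six-membered non-aromatic ring with 1 hetero atom is the first replacement for 4-carboxy-4-ethylcyclohexyl on this carbonyl carbon whose step stays within the scatter: a number 10 percentage points lower from compound 1 to compound 4 (within the scatter). Its steps from the 4-carboxy-1-methylcyclohexyl compounds also stay within the scatter, at a number 5 percentage points higher from compound 3 to compound 4 (within the scatter) and a number 10 percentage points higher from compound 2 to compound 4 (within the scatter). This position therefore accepts the added ring with no change that this read-out can separate from the scatter. From the compounds shown here alone, what an amine or a primary amide would give in place of the carboxylic acid remains open. No available evidence speaks to what sets the value of compound 4.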